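A few compounds are considered here, and "the series" means these few. Any claim that something is new, unique, unknown or untested is made for them only; others in the source may bear on it.

Compound 1 `CCCNc1nnc(SCC(=O)N(Cc2cccc([N+](=O)[O-])c2)c2ccc(F)cc2)s1` gives 25.1% in an assay on isolated protein for inhibition of Amine oxidase [flavin-containing] A (Homo sapiens), read by fluorescence and Amplex Red, with a stated time of 30 min, tested at 0.01 uM; a higher number here means a stronger effect of the compound at the concentration tested, a lower number a weaker effect.
Compound 2 `CC(C)CNc1nnc(SCC(=O)N(Cc2cccc([N+](=O)[O-])c2)c2ccc(F)cc2)s1` gives 25.5% in this assay.
Compound 3 `C=CCNc1nnc(SCC(=O)N(Cc2cccc([N+](=O)[O-])c2)c2ccc(F)cc2)s1` gives 32.7% in this assay.

All three share one core and differ only in the small chain on the nitrogen attached to the aromatic ring. Compound 3 carries the highest of the three numbers, yet both a number 7.6 percentage points higher from compound 1 to compound 3 (within the scatter) and a number 7.2 percentage points higher from compound 2 to compound 3 (within the scatter) lie within the scatter, as does a number 0.4 percentage points higher from compound 1 to compound 2 (within the scatter), so the three compounds cannot be told apart with confidence.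

Compound 4 `CC(C)Nc1nnc(SCC(=O)N(Cc2cccc([N+](=O)[O-])c2)c2ccc(F)cc2)s1` is the next member: isopropyl in place of allyl on a nitrogen on an aromatic ring. Every measured step that swaps one small chain for another on this nitrogen stayed within the scatter, and none of them pointed to a clear direction, so no step beyond the scatter is expected in this assay from compound 3 to compound 4 either; the expected step is a number 5.7 percentage points lower from compound 3 to compound 4 (within the scatter). Compound 4 is therefore estimated to give 27% in this assay, with a likely range from 15% to 38%.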

Compound 4, a percentage reported as inhibition, at one concentration (the size of the read-out at that concentration, not a potency): 23.9%
The estimate for compound 4 lay 3.1 percentage points above the measured number; measured number inside the range.
By their numbers in this assay, from the lowest: compounds 4, 1, 2 and 3 (each within the scatter of the next).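

Isopropyl brings a chain branched at the carbon on this nitrogen, and even so the number in this assay shows no step beyond the scatter against any of the other three chains (a number 8.8 percentage points lower from compound 3 to compound 4 (within the scatter); a number 1.6 percentage points lower from compound 2 to compound 4 (within the scatter); a number 1.2 percentage points lower from compound 1 to compound 4 (within the scatter)). Allyl and isopropyl hold the same count of carbons, so the first of these steps removes the double bond outside aromatic rings and adds a branch, and this double change still leaves the two compounds indistinguishable. No measurement at hand offers an explanation for this flat picture.

From the compounds shown here alone, it remains open whether a longer chain such as hexyl, or a cyclopropyl ring, would shift the number beyond the scatter at this nitrogen. The same holds for a chain ending in a hydroxyl group or a carboxylic acid.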